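The source may hold more compounds than are shown below. What is called first, only, known or untested is meant among the compounds shown, and "the series" means these compounds.

Measured so far in an ADME assay on LLC-PK1 cells (Sus scrofa) for cytotoxicity, read by neutral red uptake; a lower number here means a stronger inhibitor, a higher number a weaker inhibitor:

compound 1 `COC(/C=C/c1ccc(O)cc1)=C1\C(=O)C=C(C)C1=O` — 3.4 ug/mL
compound 2 `COC(/C=C/c1ccccc1)=C1\C(=O)C=C(C)C1=O` — 3.4 ug/mL
compound 3 `COC(/C=C/c1ccc(Cl)cc1)=C1\C(=O)C=C(C)C1=O` — 3.1 ug/mL

Compound 3 has the lowest of the three numbers, but only just: the step of a 1.1-fold lower number from compound 1 to compound 3 (0.04 log units; within the scatter) and the step of a 1.1-fold lower number from compound 2 to compound 3 (0.04 log units; within the scatter) are both inside the scatter, so no order among the three can be read from them. The same holds for no change at the digits printed from compound 1 to compound 2 (within the scatter). Across hydroxy, hydrogen and chloro on the aromatic carbon, the read-out has not moved beyond repeat-measurement noise.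

Compound 4 `COC(/C=C/c1ccc(OC)cc1)=C1\C(=O)C=C(C)C1=O` is the next point in the same position: methoxy in place of chloro on an aromatic carbon. For the measured compounds named here, no measured step exchanges chloro for methoxy, so the nearest guidance is the set of three substituent exchanges at this aromatic carbon, every one of them flat within the scatter. A fourth exchange at the same place is therefore expected to behave alike, and the estimated step of a 1.1-fold higher number from compound 3 to compound 4 (0.03 log units; within the scatter) is expected to stay inside the scatter, with no direction that can be called.

On that basis compound 4 is estimated at 3.3 ug/mL in this assay, expected to fall between 1.8 ug/mL and 6 ug/mL.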

Compound 4, half-maximal inhibitory concentration: 3.9 ug/mL
Estimate against measurement, compound 4: 1.2-fold (0.07 log units) below, and the stated range covers the measured number.
By their numbers in this assay, from the lowest: compounds 3, 1, 2 and 4 (each within the scatter of the next).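

In this assay the position on an aromatic carbon para to a large group stays flat with methoxy as well, which enters with 2 heavy atoms and 1 hydrogen-bond acceptor in place of the single chlorine: the record reads a 1.3-fold higher number from compound 3 to compound 4 (0.10 log units; within the scatter) and sits inside the scatter as printed. Against the unsubstituted ring the same holds, with a 1.1-fold higher number from compound 2 to compound 4 (0.06 log units; within the scatter) as the step, so a substituent of two heavy atoms is now included among the exchanges that leave the read-out unresolved. The series also gains its first exchange on the substituent's own oxygen, methyl for hydrogen, in a 1.1-fold higher number from compound 1 to compound 4 (0.06 log units; within the scatter) and this too gives no separable difference among hydroxy, hydrogen, chloro and methoxy. Nothing available bears on why the read-out stays flat here.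

As far as these compounds go, whether this flatness extends to an amine, a carboxylic acid or a longer chain such as butoxy at the same aromatic carbon remains open. Equally open, from the compounds shown here alone, is how the read-out responds to changes away from this position, such as replacing the methoxy on the shared core with ethoxy or the methyl on the core with hydrogen.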